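Swapping 2-fluorobenzyl for 2-bromobenzyl

The compounds below may be only part of what the source reports. "The series", "measured", "known", "first", "only" and "open" are said of these compounds alone.

Compound 1 `Fc1ccccc1CSc1nnc(-c2ccncc2)n1-c1ccccc1` reads > 50000 nM in a functional assay on HepG2 cells (Homo sapiens) for inhibition, read by MTT assay, with a stated time of 48 h (on this read-out lower numbers stand for stronger inhibition and higher numbers for weaker inhibition), and this is a limit of the test, not a measured number. Compound 2 `Clc1ccccc1CSc1nnc(-c2ccncc2)n1-c1ccccc1`, with chloro in place of fluoro on an aromatic carbon, gives 15700 nM in this assay. Among the measured compounds shown here, this swap is the only measured step so far, and it amounts to an at least 3.1-fold lower number from compound 1 to compound 2 (0.50 log units; beyond the scatter), which lies beyond the usual scatter. On these data alone, its true size remains open, since it starts from a limit.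

Compound 3 `Brc1ccccc1CSc1nnc(-c2ccncc2)n1-c1ccccc1` has not yet been measured. It changes the same place on compound 1: bromo in place of fluoro on an aromatic carbon. Here bromo stands in place of fluoro, on an aromatic carbon ortho to a large group. For the measured compounds named here, the only guide is the single step to compound 2, an at least 3.1-fold lower number from compound 1 to compound 2 (0.50 log units; beyond the scatter), so a step of similar size in the same direction, towards stronger inhibition, is expected in this assay. The expected change is an at least 3.3-fold lower number from compound 1 to compound 3 (0.52 log units; beyond the scatter). For compound 3 the estimated value is 15000 nM, with an expected range from 6000 nM to 40000 nM.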

Compound 3, half-maximal inhibitory concentration: 17100 nM
For compound 3 the middle estimate is 1.1-fold (0.06 log units) below the measured one; low and high end bracket the measured number.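

Bromo in place of fluoro on this aromatic carbon gives an at least 2.9-fold lower number from compound 1 to compound 3 (0.46 log units; beyond the scatter) in this assay, so the shift seen with chloro is not confined to chloro. Between the two heavier halogens there is a 1.1-fold higher number from compound 2 to compound 3 (0.04 log units; within the scatter), so chloro and bromo cannot be told apart here, and the data show no further gain in going from one to the other. Compound 1 carries only a limit and not a measured number, so the true size of both steps that start from it stays unknown: the limit of > 50000 nM in this assay, at which 1 of the 3 values shown sits.

On these data alone, all three compounds carry a halogen at this place, so it remains open whether a methyl group, a methoxy group or an amine would read like chloro and bromo, or whether iodo would continue the series. As far as these compounds go, it is also open whether the change from 2-fluorobenzyl to 2-bromobenzyl would have a similar effect on a core other than that of compound 1.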